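The source may hold more compounds than are shown below. What is called first, only, known or untested is meant among the compounds shown, and "the series" means these compounds.

Measured compounds:
compound 1 `CCCc1ccc(NC2=CC(=O)c3nc4n(c3C2=O)[C@H]2OC[C@@H](O)[C@H]2OC4)cc1`: 4660 nM
compound 2 `O=C1C(Nc2ccc(Br)cc2)=CC(=O)c2c1nc1n2[C@H]2OC[C@@H](O)[C@H]2OC1`: 4330 nM
compound 3 `CCc1ccc(NC2=CC(=O)c3nc4n(c3C2=O)[C@H]2OC[C@@H](O)[C@H]2OC4)cc1`: 960 nM

All three numbers come from a functional assay on MCF7 cells (Homo sapiens) for inhibition, read by sulforhodamine B assay; on this read-out lower numbers stand for stronger inhibition and higher numbers for weaker inhibition. Compound 2 stands second highest of the three; its value lies within the scatter of compound 1, while compound 3 sits at a clearly lower number. Among the compounds with values here, the one measured step, a 4.9-fold lower number from compound 1 to compound 3 (0.69 log units; beyond the scatter), concerns a saturated chain on the aryl group and does not touch the change now in question.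

Compound 4 `COc1cccc(NC2=CC(=O)c3c(nc4n3[C@H]3OC[C@@H](O)[C@H]3OC4)C2=O)c1` differs from compound 2 by 3-methoxyphenyl in place of 4-bromophenyl on an amine nitrogen. Within the data shown here, no measured step bears on this exchange of aryl substituents, so no direction can be drawn from the data; compounds 1 and 3 show only that the aryl substituent can move the number beyond the scatter. Compound 4 is therefore expected to stay near compound 2, with a wide range: a 1.2-fold lower number from compound 2 to compound 4 (0.09 log units; within the scatter), giving an estimate of 3500 nM with a range from 900 nM to 14000 nM.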

Compound 4, half-maximal inhibitory concentration: 3830 nM
The estimate for compound 4 lay 1.1-fold (0.04 log units) below the measured number; measured number inside the range.
By their numbers in this assay, from the lowest: compound 3; then compounds 4, 2 and 1 (each within the scatter of the next).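

In this assay the exchange on the amine nitrogen gives a 1.1-fold lower number from compound 2 to compound 4 (0.05 log units; within the scatter) and so leaves the number within the scatter. At this position, 3-methoxyphenyl and 4-bromophenyl are therefore not told apart, although the two groups differ in substituent, substituent place and hydrogen-bond acceptor count. Nothing at hand gives a reason for this result.

Open, as far as these compounds go, is how methoxy and bromine would compare at one shared place on the aryl ring, since this pair changes both together. Also open, from the compounds shown here alone, is how a carboxylic acid or an amine on that ring would read.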